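Carboxylic acid linker swap on the pyrazolylmethyl cinnamate core

A few compounds are considered here, and "the series" means these few. Any claim that something is new, unique, unknown or untested is made for them only; others in the source may bear on it.

Compound 1 `O=C(O)/C=C/c1ccc(Cn2cccn2)cc1OCCc1ccc2ccccc2c1` is the reference point of this set. Among the compounds with values here, in an assay on CHO cells for displacement of a labelled ligand from prostaglandin E2 receptor EP2 subtype (Mus musculus), read by scintillation counting (on this read-out lower numbers stand for stronger inhibition and higher numbers for weaker inhibition), compound 1 gives 3300 nM, the only numerical value so far. Compound 2 `O=C(O)/C=C/c1ccc(Cc2ccccc2)cc1OCCc1ccc2ccccc2c1` carries phenyl in place of 1H-pyrazol-1-yl on the saturated chain carbon bound to an aromatic carbon; in this assay compound 2 returns only > 10000 nM, which is a limit of the assay rather than a number. The step of an at least 3.0-fold higher number from compound 1 to compound 2 (0.48 log units; beyond the scatter) is therefore read against (the limit of > 10000 nM in this assay, at which 1 of the 2 values shown sits).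

Compound 3 `O=C(O)COc1ccc(Cn2cccn2)cc1OCCc1ccc2ccccc2c1` differs from compound 1 elsewhere: carboxymethoxy in place of 2-carboxyethenyl on an aromatic carbon. The acid-bearing arm on the aromatic carbon ortho to the large group is exchanged while the (1H-pyrazol-1-yl)methyl group and the naphthylethoxy chain are kept. Within the data shown here, no measured step touches this arm; the single step on record concerns the pyrazole-to-phenyl swap and does not bear on the acid linker. Among the measured compounds shown here, with no guiding step, the expected change a 1.1-fold higher number from compound 1 to compound 3 (0.03 log units; within the scatter) from compound 1 to compound 3 is none beyond the scatter, with wide uncertainty. Compound 3 is thus estimated at 3500 nM in this assay, within 700 nM to 15000 nM.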

Compound 3, inhibition constant: > 10000 nM
Compound 3: only a limit was reported (the forecaster's own chance of this, stated with the estimate: 30%); at least 2.8-fold (0.45 log units) between middle value and limit.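

Exchanging 2-carboxyethenyl for carboxymethoxy on the aromatic carbon ortho to a large group gives, in this assay, an at least 3.0-fold higher number from compound 1 to compound 3 (0.48 log units; beyond the scatter). The acid-bearing arm is therefore a second place in the series where a single change weakens the read-out, in addition to the pyrazole-to-phenyl swap, even though the leaving and entering groups have the same heavy-atom count and neither carries a net charge. Compound 3 has only a limit and not a number, so the step gives a lower bound on the size of the change and no more: the limit of > 10000 nM in this assay, at which 2 of the 3 values shown sit.

Compound 1 gives 3300 nM and remains the only numerical anchor, so the compounds shown do not separate the effect of the ether oxygen in carboxymethoxy from that of losing the double bond, a question that a saturated 2-carboxyethyl arm or a 3-carboxypropyl chain would address. They also leave open whether an arm with a tetrazole in place of the carboxylic acid, or a carboxylic acid set directly on the aromatic carbon, would hold a value at or below that of compound 1.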